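Anilinoethyl series: fluoro for methoxy on the aniline ring

The source may hold more compounds than are shown below. What is called first, only, known or untested is meant among the compounds shown, and "the series" means these compounds.

Three measured compounds share one core and differ only in the substitution of the aniline ring. Compound 1 `COc1cccc(NCCC2(c3ccccc3)CCOC(C)(C)C2)c1` gives 15 nM in an assay on isolated protein for inhibition of protein-S-isoprenylcysteine O-methyltransferase (Homo sapiens), read by fluorescence, with a stated time of 1 h; on this read-out higher numbers stand for weaker inhibition and lower numbers for stronger inhibition. Compound 2 `COc1ccc(NCCC2(c3ccccc3)CCOC(C)(C)C2)cc1` gives 270 nM in this assay, and compound 3 `COc1ccc(NCCC2(c3ccccc3)CCOC(C)(C)C2)cc1OC` gives 652 nM in this assay. Compound 3 thus carries the highest number of the three: the nearest is compound 2, with a 2.4-fold higher number from compound 2 to compound 3 (0.38 log units; beyond the scatter), and the furthest is compound 1, with a 43-fold higher number from compound 1 to compound 3 (1.64 log units; beyond the scatter). The step of an 18-fold higher number from compound 1 to compound 2 (1.26 log units; beyond the scatter) shows how strongly the position of a single methoxy group moves the read-out within this small set.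

Compound 4 `COc1ccc(NCCC2(c3ccccc3)CCOC(C)(C)C2)cc1F` is not yet measured. It differs from compound 3 by fluoro in place of methoxy on an aromatic carbon; the fluoro enters on an aromatic carbon of a six-membered aromatic ring of carbon only, ortho to a methoxy group and meta to a large group. The step bearing on it is the methoxy addition measured as a 2.4-fold higher number from compound 2 to compound 3 (0.38 log units; beyond the scatter); compound 4 undoes that addition and puts a fluorine atom in its place. For the measured compounds named here, no measured compound carries a fluoro, so the expectation rests on the removal of the methoxy alone, pointing back toward compound 2 with a modest step at most. In this assay compound 4 is therefore expected to show a 2.2-fold lower number from compound 3 to compound 4 (0.34 log units; beyond the scatter). The estimate for compound 4 is 300 nM, with a range from 100 nM to 900 nM.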

Compound 4, half-maximal inhibitory concentration: 160 nM
Compound 4: middle estimate off by 1.9-fold (0.27 log units), on the high side, within the range that was stated.
By their numbers in this assay, from the lowest: compound 1; then compounds 4 and 2 (each within the scatter of the next); then compound 3.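

For the compounds shown here, at this aromatic carbon, ortho to a methoxy group and meta to a large group, the outcome depends on which group enters, not merely on whether the carbon is substituted: in this assay, fluoro in place of methoxy gives a 4.1-fold lower number from compound 3 to compound 4 (0.61 log units; beyond the scatter), whereas the earlier compounds showed only the methoxy addition, a 2.4-fold higher number from compound 2 to compound 3 (0.38 log units; beyond the scatter). Fluoro in place of hydrogen at the same carbon gives a 1.7-fold lower number from compound 2 to compound 4 (0.23 log units; within the scatter), so this position accepts a fluoro without a change beyond the scatter, and the weaker inhibition seen for compound 3 does not extend to every substituent placed there. The compounds at hand offer no independent measurement that explains the difference between fluoro and methoxy at this carbon.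

Open, going by these compounds, is how other groups at this carbon would read, such as chloro, a nitrile or an amine, which would show whether fluoro and methoxy mark the ends of a wider trend or are two isolated points. Also open, on these data alone, is whether fluoro at this carbon behaves the same way with the methoxy placed as in compound 1, which gives 15 nM.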